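Swapping the dichlorophenyl arm for a methylsulfanylphenyl arm

The source may report more compounds than this note shows. Statements on the series, on what has been measured and on what is new or still open speak of the compounds shown alone.

Compound 1 `CN(C)c1ccc(/C=C(\C(=O)c2ccc(Br)cc2)S(=O)(=O)Cc2ccc(F)cc2)cc1` and compound 2 `Cc1ccc(S/C(=C/c2ccc(Cl)c(Cl)c2)C(=O)c2ccc(Br)cc2)cc1` share a core and were tested in a functional assay on DU-145 cells (Homo sapiens) for inhibition, read by trypan blue exclusion, with a stated time of 96 h; on this read-out lower numbers stand for stronger inhibition of growth and higher numbers for weaker inhibition of growth. Compound 1 gives 50000 nM. Compound 2 gives 50000 nM, level with compound 1 within the scatter. Compound 3 `CSc1ccc(/C=C(/Sc2ccc(C)cc2)C(=O)c2ccc(Br)cc2)cc1` differs from compound 2 by 4-(methylsulfanyl)phenyl in place of 3,4-dichlorophenyl on a double-bonded chain carbon bound to a double-bonded chain carbon. Going by the values given here, no measured pair shows what this change does, so the step in this assay is expected to be none beyond the scatter. Compound 3 is estimated at 50000 nM, within 20000 nM to 50000 nM, a step of no change at the digits printed from compound 2 to compound 3 (within the scatter).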

Compound 3, concentration for 50% growth inhibition: 50000 nM
For compound 3 middle estimate and measured number coincide at the digits printed; the measured number falls inside the stated range.
By their numbers in this assay, from the lowest: compounds 1, 2 and 3 (each within the scatter of the next).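

In this assay, 4-(methylsulfanyl)phenyl in place of 3,4-dichlorophenyl gives no change at the digits printed from compound 2 to compound 3 (within the scatter). Going by these compounds alone, this is the first measured pair that differs in this one place, and it shows that these two arms cannot be told apart here. Nothing at hand gives a reason for this result. Still open, from the compounds shown here alone, is whether any other arm at this place would give a different number, such as a phenyl ring carrying a carboxylic acid or a hydroxyl group. Going by these compounds, the effect of changing the 4-bromophenyl group also remains open.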